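A few compounds are considered here, and "the series" means these few. Any claim that something is new, unique, unknown or untested is made for them only; others in the source may bear on it.

Of the compounds shown here, three have so far been measured in a functional assay on BMDM cells (Mus musculus, strain C57BL/6) for inhibition, with a stated time of 2 days; on this read-out higher numbers stand for weaker inhibition and lower numbers for stronger inhibition. Compound 1 `Nc1cccc(-c2cn(CC(=O)Nc3nc4ccccc4s3)nn2)c1` gives 1110 nM in this assay. Compound 2 `CCOC(=O)c1ccccc1SCC(=O)Nc1nccs1` gives 3980 nM, and compound 3 `Cc1csc(NC(=O)Cn2cc(-c3ccc([N+](=O)[O-])cc3)nn2)n1` gives 190 nM. Compound 1 therefore holds the second highest of the three numbers: the gap up to compound 2 lies beyond the usual scatter, and so does the larger gap down to compound 3, which has the lowest number of the three.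

Compound 4 `O=C(Cn1cc(-c2ccc(Cl)cc2)nn1)Nc1nc2ccccc2s1` has not yet been measured. It differs from compound 1 in one place: 4-chlorophenyl in place of 3-aminophenyl on an aromatic carbon. Going by the values given here, no step between two measured compounds matches this change, so the expectation rests only on the loose hint that compound 3, with its different group on the same kind of position, reaches 190 nM. On that basis a moderate drop in number is expected for the step of a 2.5-fold lower number from compound 1 to compound 4 (0.39 log units; beyond the scatter), probably beyond the scatter but not certainly so. Compound 4 is thus expected to give 450 nM, within a range from 120 nM to 1600 nM.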

Compound 4, half-maximal inhibitory concentration: 130 nM
Estimate against measurement, compound 4: 3.5-fold (0.54 log units) above, within the range that was stated.
By their numbers in this assay, from the lowest: compounds 4 and 3 (each within the scatter of the next); then compound 1; then compound 2.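

In this assay the swap to 4-chlorophenyl from 3-aminophenyl gives an 8.5-fold lower number from compound 1 to compound 4 (0.93 log units; beyond the scatter) on the shared core. Going by these compounds alone, this is the first pair of measured compounds that differ in one place, and it shows that the choice of group on this aromatic carbon can move the number well beyond the scatter, with the stronger inhibition going to the group that has no hydrogen-bond donor or acceptor. Nothing measured here accounts for why the number falls.

The swap changes both the group on the phenyl ring and its place on that ring, so the compounds shown cannot separate the two; 3-chlorophenyl and 4-aminophenyl would be the telling partners. On these data alone, how other groups at this place, such as a methoxy group or a carboxylic acid, would behave also remains open.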